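The compounds below may be only part of what the source reports. "The series", "measured", "known", "first", "only" and "open" are said of these compounds alone.

Compound 1 `CCc1ccc(NC(=O)Nn2c(CC)nc3ccccc3c2=O)cc1`: 58%
Compound 2 `CCc1nc2ccccc2c(=O)n1NC(=O)Nc1ccc(Br)cc1`: 54%
Compound 3 `CCc1nc2ccccc2c(=O)n1NC(=O)Nc1ccc(Cl)cc1`: 52%

In a functional assay on the whole organism (strain albino) with Mus musculus as the target, at a dose of 100 mg/kg by the intraperitoneal route (on this read-out lower numbers stand for less inhibition and higher numbers for more inhibition at the one dose given (going by the name of the read-out)), compound 3 stands within the scatter of both other compounds: a number 6 percentage points lower from compound 1 to compound 3 (within the scatter), and a number 2 percentage points lower from compound 2 to compound 3 (within the scatter). Compound 4 `CCc1nc2ccccc2c(=O)n1NC(=O)Nc1ccc(OC)cc1` differs from compound 3 in one place: methoxy in place of chloro on an aromatic carbon. Going by the values given here, no measured step swaps chloro for methoxy. The steps that come nearest exchange groups on the same aromatic carbon, a number 4 percentage points lower from compound 1 to compound 2 (within the scatter), a number 6 percentage points lower from compound 1 to compound 3 (within the scatter) and a number 2 percentage points lower from compound 2 to compound 3 (within the scatter), and all three stay within the scatter. On that basis the step to compound 4 is expected to show no change beyond the scatter, no change at the digits printed from compound 3 to compound 4 (within the scatter). Compound 4 is therefore estimated at 52%, within a range from 40% to 64%.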

Compound 4, a percentage reported as inhibition, in the whole organism at one dose (the size of the read-out at that dose, not a potency): 48%
Estimate against measurement, compound 4: 4 percentage points above, and the stated range covers the measured number.
By their numbers in this assay, from the lowest: compounds 4, 3, 2 and 1 (each within the scatter of the next).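

In this assay, methoxy on the aromatic carbon para to a large group stays within the scatter of all three earlier groups, with a number 4 percentage points lower from compound 3 to compound 4 (within the scatter) and a number 6 percentage points lower from compound 2 to compound 4 (within the scatter) and a number 10 percentage points lower from compound 1 to compound 4 (within the scatter) as its steps. The position therefore holds a group carrying a hydrogen-bond acceptor as well as chloro, bromo and ethyl, with no step beyond the scatter. Nothing available explains this result.

The compounds shown leave open whether an amine, a carboxylic acid or a longer chain here would move the number beyond the scatter.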